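Bromo for Chloro on the Core of Compound 3

This account rests on a few compounds, and the source may have more. Where it says the series, first, only, none or still open, it means among the compounds named here.

Of the compounds shown here, three built on one shared core have been measured in an assay on frontal cortex for displacement of a labelled ligand from corticotropin-releasing factor receptor 1 (Rattus norvegicus), with a stated time of 2 h; on this read-out lower numbers stand for stronger inhibition and higher numbers for weaker inhibition. Compound 1 `COc1cc(C)c(Nc2nc(Cl)cn([C@@H](COCCF)C3CC3)c2=O)cc1C` gives 0.46 nM in this assay, and compound 2 `COc1cc(Cl)c(Nc2nc(Br)cn([C@@H](COCCF)C3CC3)c2=O)c(Cl)c1` gives 0.46 nM. Compound 3 `COc1nc(Cl)nc(C)c1Nc1nc(Cl)cn([C@@H](COCCF)C2CC2)c1=O` gives 19 nM, the highest of the three numbers; its gap to compound 1 and its gap to compound 2 both lie beyond the usual scatter, so compound 3 stands as the weakest inhibitor of the three.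

Compound 4 `COc1nc(Cl)nc(C)c1Nc1nc(Br)cn([C@@H](COCCF)C2CC2)c1=O` has not yet been measured. It differs from compound 3 in one place: bromo in place of chloro on an aromatic carbon. Among the compounds with values here, no measured pair in this set shows this exchange on its own; compound 1 and compound 2 carry chloro and bromo at that carbon but also differ in their other substituents, and their two values are alike, which gives no hint of a large effect from the halogen itself. On that basis the step from compound 3 to compound 4 is expected to be small, with no clear direction, and to stay within the usual scatter of this assay. Compound 4 is therefore estimated to give 15 nM in this assay, with a range from 6 nM to 45 nM, and the expected step is a 1.3-fold lower number from compound 3 to compound 4 (0.10 log units; within the scatter).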

Compound 4, half-maximal inhibitory concentration in the corticotropin-releasing factor receptor 1 assay: 14 nM
Compound 4: middle estimate off by 1.1-fold (0.03 log units), on the high side, within the range that was stated.
By their numbers in the corticotropin-releasing factor receptor 1 assay, from the lowest: compounds 1 and 2 (each within the scatter of the next); then compounds 4 and 3 (each within the scatter of the next).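

Taken alone, with the rest of compound 3 left as it stands, the exchange of chloro for bromo on this aromatic carbon gives in the corticotropin-releasing factor receptor 1 assay a clean reading: compound 3 gives 19 nM and compound 4 gives 14 nM (a 1.4-fold lower number from compound 3 to compound 4 (0.13 log units; within the scatter)), and the two compounds cannot be told apart. Compound 1 and compound 2 could offer only a hint about this carbon, since they also differ in their other substituents, whereas this pair isolates the halogen and shows that, on this core, the larger halogen leaves the read-out within the usual scatter. The same pair in a physicochemical assay for lipophilicity, using the shake flask method, in phosphate buffer, measured as octanol-water partition, with a stated time of 40 min, at pH 7.4 (a higher number here means a more lipophilic compound, a lower number a more polar compound), also shows no separation, with compound 3 at 3.3 and compound 4 at 3.4 (a number 0.10 log units higher from compound 3 to compound 4 (within the scatter)), so neither read-out distinguishes the two halogens here, and nothing among the data shown accounts for either result.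

As far as these compounds go, only chloro and bromo have been seen at this carbon, so it remains open how the read-outs would respond to a methyl group, a nitrile or an amine there. From the compounds shown here alone, it is also open whether bromo in place of chloro would read the same way on the core of compound 1, which carries different substituents from compound 3.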